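The source may hold more compounds than are shown below. What is called first, only, known or untested is meant among the compounds shown, and "the series" means these compounds.

Measured compounds in the series:

Compound 1 `Cc1cc(C(F)(F)F)cc(NC[C@@H]2CC3(CC3)CN2C(=O)c2nc(C)sc2-c2ccccc2)n1`; in a functional assay on HEK293 cells for antagonist activity at Orexin receptor type 2 (Homo sapiens), read by FLIPR and calcium flux (a lower number here means a less potent compound, a higher number a more potent compound, by a factor of ten per unit of this negative logarithm), compound 1 gives 8.6.
Compound 2 `Cc1cccc(NC[C@@H]2CC3(CC3)CN2C(=O)c2nc(C)sc2-c2ccccc2)n1`; in this assay compound 2 gives 7.6.
Compound 3 `Cc1nc(C(=O)N2CCC3(CC3)C[C@H]2CNc2ccc(C(F)(F)F)cn2)c(-c2ccccc2)s1`; in this assay compound 3 is reported only as a limit, < 5.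

For the measured compounds named here, compound 2 stands at the lower of the two numbers in this assay; the only measured step, a number 1.00 log units lower from compound 1 to compound 2 (beyond the scatter), runs from the trifluoromethyl compound down to it, and the remaining entry is the limit described by the limit of < 5 in this assay, at which 1 of the 3 values shown sits.

Compound 4 `Cc1ccnc(NC[C@@H]2CC3(CC3)CN2C(=O)c2nc(C)sc2-c2ccccc2)n1` has not been measured in this assay. The change from compound 2 is 4-methylpyrimidin-2-yl in place of 6-methylpyridin-2-yl on an amine nitrogen. Going by the values given here, no measured step alters the aromatic ring on the amine nitrogen itself; the one step in hand concerns a substituent on that ring, and compound 3, which differs from compound 2 in more than one place, gives no step. The expectation therefore rests on the shared core being kept and the aryl amine being retained in size, and a step of a number 0.10 log units lower from compound 2 to compound 4 (within the scatter) within the scatter is expected from compound 2 to compound 4.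

For compound 4 the estimate in this assay is 7.5, with a range from 6.5 to 8.4.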

Compound 4, negative logarithm of the antagonist equilibrium constant: 7
For compound 4 the middle estimate is 0.50 log units above the measured one; the measured number falls inside the stated range.
By their numbers in this assay, from the lowest: compound 4; then compound 2; then compound 1. At a limit, below all of these: compound 3.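

The aromatic ring on the amine nitrogen responds in this assay to a change in the ring itself, and not only to a change in its substituents: 4-methylpyrimidin-2-yl in place of 6-methylpyridin-2-yl gives a number 0.60 log units lower from compound 2 to compound 4 (beyond the scatter) with the heavy-atom count unchanged. Measured against the trifluoromethyl-bearing group, the same position gives a number 1.60 log units lower from compound 1 to compound 4 (beyond the scatter) and this is a larger step than the loss of trifluoromethyl alone, which gives a number 1.00 log units lower from compound 1 to compound 2 (beyond the scatter) on the pyridine ring. No measurement at hand bears on what lies behind these steps.

From the compounds shown here alone, it remains open whether a trifluoromethyl group on the pyrimidine ring would recover the value of compound 1, as it does on the pyridine ring, or whether the two changes would not add up in that way. Also open, going by these compounds, is how other rings on the amine nitrogen, such as a pyrazine or a plain phenyl, and other substituents, such as a methoxy group or a chlorine in place of methyl, would read in this assay on the shared core.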